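This account rests on a few compounds, and the source may have more. Where it says the series, first, only, none or still open, it means among the compounds named here.

Compound 1 `C[C@H]1CC[C@@H]2[C@@H](OC(=O)[C@]23CC(c2ccccc2[N+](=O)[O-])=NO3)[C@]2(C)C(=O)C=C[C@@]12O`: 37000 nM
Compound 2 `C[C@H]1CC[C@@H]2[C@@H](OC(=O)[C@]23CC(c2ccccc2Cl)=NO3)[C@]2(C)C(=O)C=C[C@@]12O`: 12000 nM
Compound 3 `Cc1cccc(C2=NO[C@]3(C2)C(=O)O[C@@H]2[C@H]3CC[C@H](C)[C@]3(O)C=CC(=O)[C@@]23C)c1`: 66600 nM

In a functional assay on PC-3 cells (Homo sapiens) for cytotoxicity, read by sulforhodamine B assay, with a stated time of 48 h (a lower number here means a stronger inhibitor, a higher number a weaker inhibitor), compound 1 stands second highest of the three values; compound 3 lies nearest to it, and compound 2 furthest, the step of a 3.1-fold lower number from compound 1 to compound 2 (0.49 log units; beyond the scatter) being beyond the scatter. Compound 4 `Cc1ccc(C2=NO[C@]3(C2)C(=O)O[C@@H]2[C@H]3CC[C@H](C)[C@]3(O)C=CC(=O)[C@@]23C)cc1` differs from compound 1 in one place: 4-methylphenyl in place of 2-nitrophenyl on a carbon with a double bond to nitrogen. Within the data shown here, two measured steps bear on this change, both exchanging the group on the carbon with a double bond to nitrogen: a 1.8-fold higher number from compound 1 to compound 3 (0.26 log units; within the scatter), within the scatter, and a 5.6-fold higher number from compound 2 to compound 3 (0.74 log units; beyond the scatter), beyond it. A methylphenyl group in place of the nitrophenyl group thus left the number near or somewhat above that of compound 1. The same is expected for compound 4, with a step of a 1.4-fold higher number from compound 1 to compound 4 (0.13 log units; within the scatter) that should stay within the scatter. The estimate for compound 4 is 50000 nM, with a range of 20000 nM to 130000 nM.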

Compound 4, half-maximal inhibitory concentration: 14000 nM
The estimate for compound 4 lay 3.6-fold (0.55 log units) above the measured number; the whole stated range lies above it.
By their numbers in this assay, from the lowest: compounds 2 and 4 (each within the scatter of the next); then compounds 1 and 3 (each within the scatter of the next).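

In this assay, among these compounds, moving the methyl group of the methylphenyl substituent changes the result (a 4.8-fold lower number from compound 3 to compound 4 (0.68 log units; beyond the scatter)), a difference the earlier compounds could not show. The 4-methylphenyl group also departs from the 2-nitrophenyl group (a 2.6-fold lower number from compound 1 to compound 4 (0.42 log units; beyond the scatter)), yet it is level with the 2-chlorophenyl group (a 1.2-fold higher number from compound 2 to compound 4 (0.07 log units; within the scatter)). No measurement offered here accounts for these steps.

Still open, on these data alone, is how an amine, a carboxylic acid or a longer chain in place of the methyl group of 4-methylphenyl would read in this assay. As far as these compounds go, whether the gap between 3-methylphenyl and 4-methylphenyl extends to such groups also remains open.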